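The source may hold more compounds than are shown below. What is called first, only, known or untested is meant among the compounds shown, and "the series" means these compounds.

Measured so far in a functional assay on HCT-116 cells (Homo sapiens) for inhibition, read by MTT assay, with a stated time of 48 h; a lower number here means a stronger inhibitor, a higher number a weaker inhibitor:
- Compound 1 `COc1ccc(-n2c(S)nnc2-c2cc(OC)c(OC)c(OC)c2)cc1`: > 60000 nM, a limit
- Compound 2 `COc1ccc(-n2c(SC)nnc2-c2cc(OC)c(OC)c(OC)c2)cc1`: > 60000 nM, a limit
- Compound 3 `COc1ccc(-n2c(SCc3ccc(C)cc3)nnc2-c2cc(OC)c(OC)c(OC)c2)cc1`: 33300 nM

Of these three, only compound 3 has an actual number, 33300 nM. The other two values are limits: the limit of > 60000 nM in this assay, at which 2 of the 3 values shown sit. Compound 4 `COc1ccc(CSc2nnc(-c3cc(OC)c(OC)c(OC)c3)n2-c2ccc(OC)cc2)cc1` differs from compound 3 in one place: methoxy in place of methyl on an aromatic carbon. Methoxy stands in place of methyl on an aromatic carbon, turning 4-methylbenzyl into 4-methoxybenzyl. The nearest measured steps are those that bring the 4-methylbenzyl group onto the sulfur, an at least 1.8-fold lower number from compound 1 to compound 3 (0.25 log units; that floor lies within the scatter) and an at least 1.8-fold lower number from compound 2 to compound 3 (0.25 log units; that floor lies within the scatter), and neither floor exceeds the scatter. Neither step varies the methyl itself, so no step beyond the scatter is expected in this assay, in either direction. The estimated step is a 1.2-fold lower number from compound 3 to compound 4 (0.08 log units; within the scatter). Compound 4 is expected at 28000 nM, within an estimated range of 10000 nM to 60000 nM.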

Compound 4, half-maximal inhibitory concentration: 49600 nM
Compound 4: the middle estimate sits 1.8-fold (0.25 log units) below what was measured; low and high end bracket the measured number.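

In this assay, within the data shown here, this is the first change made on the 4-methylbenzyl group itself, and it gives a 1.5-fold higher number from compound 3 to compound 4 (0.17 log units; within the scatter), so methoxy and methyl at this place read alike. Set against the smaller sulfur substituents, the 4-methoxybenzyl group gives an at least 1.2-fold lower number from compound 1 to compound 4 (0.08 log units; that floor lies within the scatter) and an at least 1.2-fold lower number from compound 2 to compound 4 (0.08 log units; that floor lies within the scatter), so neither floor shows a real gain. Both floors rest on limits: the limit of > 60000 nM in this assay, at which 2 of the 4 values shown sit.

On these data alone, whether an amine or a carboxylic acid in place of the methoxy would move the number beyond the scatter remains open. So does the effect of a longer chain on the sulfur.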